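A few compounds are considered here, and "the series" means these few. Any claim that something is new, unique, unknown or untested is made for them only; others in the source may bear on it.

The measured compounds in a toxicity assay on MRC5 cells (Homo sapiens) for inhibition, read by MTT assay, with a stated time of 72 h; on this read-out higher numbers stand for weaker inhibition and lower numbers for stronger inhibition:
Compound 1, `CCCCCCCCCCCC(=O)OCCc1ccc(O)cc1`, gives 67200 nM.
Compound 2, `CCCCCCCCCCCCCCCC(=O)OCCc1ccc(O)c(O)c1`, gives > 50000 nM, which is a limit of the assay rather than a number.
Compound 3, `CCCCCCCCCCCCSCCc1ccc(OCc2ccc(OC)cc2)c(OCc2ccc(OC)cc2)c1`, gives > 50000 nM, likewise a limit of the assay.

Compound 2 therefore has no exact position among these numbers; only a limit is known for it, and it shares that standing with compound 3 at the limit of > 50000 nM in this assay, at which 2 of the 3 values shown sit. Compound 1 is the only one of the three with a measured value, and that value lies close to the same limit, so all three show weak inhibition of the cell line.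

The next compound, compound 4, `CCCCCCCC(=O)OCCc1ccc(O)c(O)c1`, has not yet been measured in this assay. It differs from compound 2 in one place: hydrogen in place of octyl on a saturated chain carbon, seven bonds along the chain from a carbonyl carbon. The ester and the ring-bearing part of the molecule remain unchanged; only the saturated chain is shortened.

Among the compounds with values here, with no measured step of this kind among the three compounds, there is no basis to expect movement in this assay beyond the usual scatter in either direction. Compound 4 is accordingly expected to give 80000 nM, within the range 30000 nM to 300000 nM, and the step is estimated as a step that the limit leaves unreadable from compound 2 to compound 4, most likely reported again as a limit.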

Compound 4, half-maximal inhibitory concentration: 104000 nM
The estimate for compound 4 lay 1.3-fold (0.11 log units) below the measured number; low and high end bracket the measured number.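

No size can be read for the change from compound 2 to compound 4 in this assay, because compound 2 has only a limit there and not a number: the limit of > 50000 nM in this assay, at which 2 of the 4 values shown sit.

The compounds shown leave open whether hydrogen in place of octyl on a saturated chain carbon moves the result in this assay in either direction.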